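Bcl-2 series: amide variation from compound 3 to compound 4

The source may hold more compounds than are shown below. What is called first, only, known or untested is meant among the compounds shown, and "the series" means these compounds.

Measured in an assay on isolated protein for inhibition of Apoptosis regulator Bcl-2 (Homo sapiens), read by fluorescence polarization, with stated times of 5 min and 10 min; on this read-out higher numbers stand for weaker inhibition and lower numbers for stronger inhibition:
compound 1 `CC(C)=CCCC1=CC[C@@H](C(=O)Nc2ccc(C(=O)O)cc2)[C@H](c2ccccc2)C1` gives 2200 nM.
compound 2 `CC1(C)CCCC2=C1C[C@@H](C(=O)O)[C@H](c1ccccc1)C2` gives > 23000 nM, a limit of the assay.
compound 3 `CC(C)=CCCC1=CC[C@H](C(=O)Nc2ccc(O)cc2)[C@@H](c2ccccc2)C1` gives > 23000 nM, also a limit of the assay.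

Compound 3 thus stands at the limit rather than at a number, as shown by the limit of > 23000 nM in this assay, at which 2 of the 3 values shown sit, so no order between compound 3 and compound 2 can be read, while compound 1 alone returns a number. Compound 4 `CC(C)=CCCC1=CC[C@H](C(=O)N(C)C)[C@@H](c2ccccc2)C1` differs from compound 3 in one place: dimethylamino in place of (4-hydroxyphenyl)amino on a carbonyl carbon. Among the compounds with values here, no measured pair differs in only this place, so the size of this step is not known from the values shown. No step beyond the scatter is expected in this assay in either direction, and a further limit is likely. Compound 4 is expected to give 30000 nM, within 8000 nM to 100000 nM, an expected step that the limit leaves unreadable from compound 3 to compound 4.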

Compound 4, inhibition constant: > 23000 nM
Compound 4 was reported as a limit (the forecaster's own chance of this, stated with the estimate: 70%); the middle value does not contradict the limit.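

Within the data shown here, compound 3 and compound 4 both sit at a limit, so no step between them can be read: the limit of > 23000 nM in this assay, at which 3 of the 4 values shown sit.
The compounds shown leave open what dimethylamino in place of (4-hydroxyphenyl)amino on the carbonyl carbon is worth in this assay.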